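The compounds below may be only part of what the source reports. "The series", "measured", "known", "first", "only" and "open" are said of these compounds alone.

The measured compounds:
compound 1, `O=C(O)c1ccc(C(=O)/C(=C\c2ccc(F)c([N+](=O)[O-])c2)SCc2ccc(Cl)cc2)cc1`, with 50000 nM;
compound 2, `O=C(/C(=C\c1ccc([N+](=O)[O-])c(O)c1)SCc1ccc(Br)cc1)c1c(F)c(F)c(F)c(F)c1F`, with 10000 nM;
compound 3, `O=C(/C(=C/c1ccc(Cl)cc1)Cc1c[nH]c2ccccc12)c1ccc(Cl)cc1Cl`, with 10000 nM.

All three were tested in a functional assay on DU-145 cells (Homo sapiens) for inhibition, read by trypan blue exclusion, with a stated time of 96 h; a higher number here means a weaker inhibitor of growth, a lower number a stronger inhibitor of growth. Compound 1 stands at the highest of the three numbers: compound 2 and compound 3 each sit at a lower number, and each of those gaps lies beyond the scatter. Compound 2 and compound 3 share the same value, so nothing separates them from each other. Among the compounds with values here, no pair among the three differs in only one place, so no single step between measured compounds can be read off.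

Compound 4, `O=C(O)c1ccc(C(=O)/C(=C\c2ccc(F)c([N+](=O)[O-])c2)SCc2ccc(F)cc2)cc1`, has not yet been measured. It differs from compound 1 in one place: fluoro in place of chloro on an aromatic carbon. Within the data shown here, nothing among the measured compounds shows how this exchange alone moves the number in this assay, as no two of them differ by it. One heavy atom is exchanged for another of the same kind of group at the same place on the ring, and such an exchange is expected to leave the number roughly where it is. The step from compound 1 to compound 4 is therefore expected to be small, no change at the digits printed from compound 1 to compound 4 (within the scatter), with no direction beyond the scatter. Compound 4 is estimated at 50000 nM, within a range of 20000 nM to 120000 nM.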

Compound 4, concentration for 50% growth inhibition: 1000 nM
Estimate against measurement, compound 4: 50-fold (1.70 log units) above; the whole stated range lies above it.
By their numbers in this assay, from the lowest: compound 4; then compounds 2 and 3 (each within the scatter of the next); then compound 1.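

In this assay, fluoro in place of chloro on an aromatic carbon, para to a large group, gives a 50-fold lower number from compound 1 to compound 4 (1.70 log units; beyond the scatter). Within the data shown here, this is the first single step that can be read in this set, as no earlier pair differed in only one place, and it shows that the number is highly sensitive to the atom held at this position of the 4-chlorobenzyl group. The size of the step stands against how little the counted difference is: one heavy atom leaves, one heavy atom enters, and no ring, hydrogen-bond donor, hydrogen-bond acceptor or net charge comes or goes. Nothing measured here bears on why the number moves so far.

The compounds shown leave open how the number responds when this position carries hydrogen, methoxy or trifluoromethyl, so a single exchange cannot yet be placed within a wider series. They also leave open whether fluoro in place of chloro gives a step of similar size when a methyl ester or a primary amide stands in place of the carboxylic acid on the core of compound 4.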